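The compounds below may be only part of what the source reports. "The series", "measured", "known", "first", "only" and "open" are said of these compounds alone.

Compound 2 `NC[C@@H]1CCN(c2cc3c(cc2F)c(=O)c(C(=O)O)cn3Cc2ccc(-c3ccccc3)cc2)C1` gives 15600 nM in an assay on isolated protein for inhibition of DNA topoisomerase 1 (Homo sapiens), with a stated time of 15 min; on this read-out lower numbers stand for stronger inhibition and higher numbers for weaker inhibition. Compound 1 `O=C(O)c1cn(Cc2ccc(-n3cccn3)cc2)c2cc(N3C[C@H]4CCNC[C@H]4C3)c(F)cc2c1=O` gives 31300 nM. Compound 3 `NC[C@@H]1CCN(c2cc3c(cc2F)c(=O)c(C(=O)O)cn3Cc2ccc(-c3ccc(F)cc3)cc2)C1` gives 69600 nM.

Among these three, compound 2 shows the lowest number, although compound 1 differs from it only within the usual scatter of repeated measurements. Going by the values given here, the one measured step, a 4.5-fold higher number from compound 2 to compound 3 (0.65 log units; beyond the scatter), is the sole change that reaches beyond the scatter. Compound 4 `O=C(O)c1cn(Cc2ccc(-c3ccccc3)cc2)c2cc(N3C[C@H]4CCNC[C@H]4C3)c(F)cc2c1=O` differs from compound 2 in one place: a group of 9 heavy atoms (7 carbon, 2 nitrogen; one five-membered non-aromatic ring with 1 hetero atom, one six-membered non-aromatic ring with 1 hetero atom) in place of a group of 7 heavy atoms (5 carbon, 2 nitrogen; one five-membered non-aromatic ring with 1 hetero atom), on an aromatic carbon. Among the compounds with values here, no measured step makes this same exchange, and the step from compound 2 to compound 3 concerns a different change. Compound 1 carries the same entering group as compound 4 but differs from it elsewhere, so its number can only be set beside that of compound 2. In this assay, no step beyond the scatter is therefore expected: a 1.3-fold higher number from compound 2 to compound 4 (0.11 log units; within the scatter). Compound 4 is estimated at 20000 nM, with a range from 7000 nM to 60000 nM.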

Compound 4, half-maximal inhibitory concentration: 61000 nM
Compound 4: middle estimate off by 3.1-fold (0.48 log units), on the low side; measured number above the stated range.
By their numbers in this assay, from the lowest: compounds 2, 1, 4 and 3 (each within the scatter of the next, the first and the last beyond it).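

In this assay, placing the two-ring group of 9 heavy atoms on this aromatic carbon instead of 3-(aminomethyl)pyrrolidin-1-yl gives a 3.9-fold higher number from compound 2 to compound 4 (0.59 log units; beyond the scatter), so the number responds to the group held at this position. By contrast, phenyl in place of 1H-pyrazol-1-yl gives a 1.9-fold higher number from compound 1 to compound 4 (0.29 log units; within the scatter), which shows no clear effect of that exchange. No measurement at hand explains either step. Still open, on these data alone, is how a piperazin-1-yl group, or the longer-chained 3-(2-aminoethyl)pyrrolidin-1-yl, would read at this position.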